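Compound 4 and a second halogenated amide aryl group

The source may report more compounds than this note shows. Statements on the series, on what has been measured and on what is new or still open speak of the compounds shown alone.

Compound 3 `Cc1cc(Cl)ccc1C(=O)Nc1ccc(Cl)c(-c2nnc3c(Cl)cccn23)c1` is one of three amides sharing a core; its value in a functional assay on A549 cells (Homo sapiens) for antiproliferative activity, read by MTT assay, with a stated time of 72 h (a lower number here means a stronger inhibitor, a higher number a weaker inhibitor), is only a limit, > 100000 nM, a limit at which compound 3 sits together with one other compound (the limit of > 100000 nM in this assay, at which 2 of the 3 values shown sit). Compound 1 `O=C(Nc1ccc(Cl)c(-c2nnc3c(Cl)cccn23)c1)c1cccnc1` also gives only the limit > 100000 nM in this assay. Compound 2 `O=C(Nc1ccc(Cl)c(-c2nnc3c(Cl)cccn23)c1)c1cccc(Cl)c1` gives 52700 nM in this assay, and an at least 1.8-fold higher number from compound 2 to compound 3 (0.27 log units; that floor lies within the scatter). The step that the two limits leave unreadable from compound 1 to compound 3 cannot be read. Compound 4 `O=C(Nc1ccc(Cl)c(-c2nnc3c(Cl)cccn23)c1)c1c(F)cccc1Cl` differs from compound 3 in 2-chloro-6-fluorophenyl in place of 4-chloro-2-methylphenyl on a carbonyl carbon. With compound 3 at a limit and its neighbours at or near it, compound 4 is expected to lie near the same limit, with an at least 1.1-fold lower number from compound 3 to compound 4 (0.04 log units; that floor lies within the scatter), so its estimated value in this assay is 90000 nM within 30000 nM to 250000 nM.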

Compound 4, half-maximal inhibitory concentration: 72300 nM
Compound 4: the middle estimate sits 1.2-fold (0.10 log units) above what was measured; measured number inside the range.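

In this assay, compound 4 joins compound 2 in giving a number rather than a limit, which the other two amides do not: the limit of > 100000 nM in this assay, at which 2 of the 4 values shown sit. The step is a 1.4-fold higher number from compound 2 to compound 4 (0.14 log units; within the scatter), so 3-chlorophenyl and 2-chloro-6-fluorophenyl cannot be told apart on this carbonyl carbon. The steps of an at least 1.3-fold lower number from compound 3 to compound 4 (0.14 log units; that floor lies within the scatter) and an at least 1.3-fold lower number from compound 1 to compound 4 (0.14 log units; that floor lies within the scatter) rest on limits and give only floors.

As far as these compounds go, what an amine, a carboxylic acid or a longer chain in place of the aryl group on this carbonyl carbon would give in this assay stays open.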